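This account rests on a few compounds, and the source may have more. Where it says the series, first, only, none or still open, it means among the compounds named here.

Working notes on the series, following the move from compound 3 to compound 4.

Three compounds of the shared core have been run in a functional assay on CCRF-CEM cells for antagonist activity at C-X-C chemokine receptor type 4 (Homo sapiens), read by calcium flux, with stated times of 25 min and 90 s; on this read-out higher numbers stand for weaker inhibition and lower numbers for stronger inhibition. Compound 3 `CN(C[C@H]1Cc2c(cccc2N2CCN(Cc3ccccn3)CC2)CN1)[C@H]1CCCc2cccnc21` gives 4.47 nM, the lowest of the three numbers. Compound 2 `CN(C[C@H]1Cc2c(cccc2N2CCN(C3CC3)CC2)CN1)[C@H]1CCCc2cccnc21` gives 23.5 nM, and compound 1 `CN(C[C@H]1Cc2c(cccc2N2CCN(C3COC3)CC2)CN1)[C@H]1CCCc2cccnc21` gives 381 nM. All three steps lie beyond the scatter: a 16-fold lower number from compound 1 to compound 2 (1.21 log units; beyond the scatter), an 85-fold lower number from compound 1 to compound 3 (1.93 log units; beyond the scatter), and a 5.3-fold lower number from compound 2 to compound 3 (0.72 log units; beyond the scatter). Every one of them changes only the group on the ring nitrogen of the six-membered non-aromatic ring with two nitrogens.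

Compound 4 `CN(C[C@H]1Cc2c(cccc2N2CCN(c3cccc(C(F)(F)F)c3)CC2)CN1)[C@H]1CCCc2cccnc21` changes the same position: 3-(trifluoromethyl)phenyl in place of (pyridin-2-yl)methyl on an amine nitrogen in a ring. For the measured compounds named here, none of the measured steps puts an aromatic ring directly on that nitrogen, so the nearest guide is the comparison of compound 2 with compound 3, where the group carrying a six-membered aromatic ring with one hetero atom gave the lowest number. Compound 4 keeps a six-membered aromatic ring but loses the hydrogen-bond acceptor and the one-carbon link. The expectation for compound 4 in this assay is therefore a somewhat higher number than compound 3, with wide uncertainty: a step of a 4.5-fold higher number from compound 3 to compound 4 (0.65 log units; beyond the scatter) is estimated. Compound 4 is expected to give about 20 nM, between 4 nM and 120 nM.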

Compound 4, half-maximal inhibitory concentration: > 16700 nM
Compound 4: a limit, no number (the forecaster's own chance of this, stated with the estimate: 3%); middle value at least 830-fold (2.92 log units) from the limit.
By their numbers in this assay, from the lowest: compound 3; then compound 2; then compound 1. At a limit, above all of these: compound 4.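

In this assay compound 4 gives no number, only a limit: the limit of > 16700 nM in this assay, at which 1 of the 4 values shown sits.

Against each earlier group the change is large: an at least 3700-fold higher number from compound 3 to compound 4 (3.57 log units; beyond the scatter), an at least 710-fold higher number from compound 2 to compound 4 (2.85 log units; beyond the scatter), and an at least 43-fold higher number from compound 1 to compound 4 (1.64 log units; beyond the scatter). The earlier compounds shown here showed this position moving a measured number, with oxetan-3-yl, cyclopropyl and (pyridin-2-yl)methyl all giving values; compound 4 shows that a group on this amine nitrogen in a ring can also take the read-out past the limit of the assay, so that even the oxetan-3-yl of compound 1 stands well clear of 3-(trifluoromethyl)phenyl.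

The step from compound 3 to compound 4 changes several things at once: the one-carbon link, the ring nitrogen of the aromatic ring and the trifluoromethyl group, and the compounds shown do not tell which of these accounts for the loss. A plain phenyl, a pyridin-2-yl or a 3-(trifluoromethyl)benzyl on the same nitrogen would separate them, and none of these stands among the compounds shown.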